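The source may hold more compounds than are shown below. What is called first, only, known or untested is meant among the compounds shown, and "the series" means these compounds.

Measured in a functional assay on NCI-H460 cells (Homo sapiens) for inhibition, read by CCK-8 assay, with a stated time of 48 h; a lower number here means a stronger inhibitor, a higher number a weaker inhibitor:
compound 1 `COc1ccc(NC(=S)NC(=O)c2cn(-c3ccccc3)nc2-c2ccc(OC)cc2)cc1` gives 2570 nM
compound 2 `COc1ccc(-c2nn(-c3ccccc3)cc2C(=O)NC(=S)Nc2ccc(F)cc2)cc1` gives 3050 nM
compound 3 `COc1ccc(-c2nn(-c3ccccc3)cc2C(=O)NC(=S)Nc2ccc(Cl)cc2)cc1` gives 3010 nM

Compound 2 sits among these three with its number inside the scatter of both others: the step of a 1.2-fold higher number from compound 1 to compound 2 (0.07 log units; within the scatter) and the step of a 1.0-fold lower number from compound 2 to compound 3 (0.01 log units; within the scatter) each stay within the usual spread of repeats, as does a 1.2-fold higher number from compound 1 to compound 3 (0.07 log units; within the scatter). Nothing separates the three on the evidence here.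

Compound 4 `O=C(NC(=S)Nc1ccc(F)cc1)c1cn(-c2ccccc2)nc1-c1ccc(Cl)cc1` differs from compound 2 by chloro in place of methoxy on an aromatic carbon. This change sits on the aromatic ring attached to the shared core, whereas all three measured changes lie on the other six-membered aromatic ring of carbon only. The closest measured step is a 1.2-fold higher number from compound 1 to compound 3 (0.07 log units; within the scatter), the same swap of methoxy for chloro on an aromatic carbon at that other place, and it stayed within the scatter; the step of a 1.0-fold lower number from compound 2 to compound 3 (0.01 log units; within the scatter) was likewise flat. Going by the values given here, no measured step tests the ring on the core itself, so the comparison is indirect. On this basis the expected step of a 1.0-fold lower number from compound 2 to compound 4 (0.01 log units; within the scatter) in this assay is none beyond the scatter, in either direction. As far as these compounds go, for compound 4 the estimate in this assay is 3000 nM, with a range from 1400 nM to 6500 nM, the width reflecting that the place of the change is untested.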

Compound 4, half-maximal inhibitory concentration: 3640 nM
Estimate against measurement, compound 4: 1.2-fold (0.08 log units) below; low and high end bracket the measured number.
By their numbers in this assay, from the lowest: compounds 1, 3, 2 and 4 (each within the scatter of the next).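

The change from 4-methoxyphenyl to 4-chlorophenyl on the ring attached to the shared core now has a direct reading in this assay: the step of a 1.2-fold higher number from compound 2 to compound 4 (0.08 log units; within the scatter) stays within the usual spread of repeats. Going by these compounds alone, all earlier steps lay on the other aromatic ring, so this is the first evidence from this position, and on that evidence methoxy and chloro here cannot be told apart. The swap also reads the same at both places where it occurs, which gives no sign so far that its outcome depends on the surrounding compound: the same change on two cores in this assay, a 1.2-fold higher number (0.07 log units; within the scatter) from compound 1 to compound 3 and a 1.2-fold higher number (0.08 log units; within the scatter) from compound 2 to compound 4, 1.0-fold (0.01 log units) apart, within the scatter of two such steps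

Only methoxy and chloro are shown at this position, so its tolerance is defined by just two groups and the range of the response remains unknown. Whether an amine, a carboxylic acid or a longer alkoxy chain at this place would move the number beyond the scatter stays open, as does whether this flat reading extends to cell lines other than the one shown.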